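This account rests on a few compounds, and the source may have more. Where it says the series, first, only, none or still open, it means among the compounds named here.

In an ADME assay on microsomes from liver (Rattus norvegicus) for metabolic stability, with a stated time of 10 min (on this read-out lower numbers stand for a less stable compound and higher numbers for a more stable compound), compound 3 `CC(C)(C)OC(=O)NCCS(=O)(=O)NC(=O)c1ccc(Nc2nc(NC3(c4ccc(Cl)cc4)CC3)nc(OCC(F)(F)F)n2)cc1` gives 93%, the second highest of three numbers. Compound 1 `CC(C)NCCS(=O)(=O)NC(=O)c1ccc(Nc2nc(NC3(c4ccc(Cl)cc4)CC3)nc(OCC(F)(F)F)n2)cc1` gives 100%, and the step of a number 7 percentage points lower from compound 1 to compound 3 (within the scatter) lies within the scatter. Compound 2 `CCCCCNc1nc(Nc2ccc([N+](=O)[O-])cc2)nc(OCC(F)(F)F)n1` gives 35%, a number far below compound 3 and beyond the scatter. Compound 4 `O=C(NS(=O)(=O)CCNC(=O)C1CC1)c1ccc(Nc2nc(NC3(c4ccc(Cl)cc4)CC3)nc(OCC(F)(F)F)n2)cc1` differs from compound 3 by cyclopropyl in place of tert-butoxy on a carbonyl carbon. Going by the values given here, the only measured step touching this end of the molecule is a number 7 percentage points lower from compound 1 to compound 3 (within the scatter), a small change, so a further swap at the same end is expected to shift this assay little if at all. For compound 4 the expected change is a number 3 percentage points lower from compound 3 to compound 4 (within the scatter), no step beyond the scatter. Compound 4 is therefore estimated at 90%, between 72% and 100%.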

Compound 4, percent of the compound remaining: "not active" (no number reported)
Compound 4 has no reported number here; there is nothing to compare the estimate with.
By their numbers in this assay, from the lowest: compound 2; then compounds 3 and 1 (each within the scatter of the next).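

Going by these compounds alone, compound 4 carries only the entry "not active" in this assay, without a number, so no step from compound 3 can be read, and no evidence bears on this result. Going by these compounds, how cyclopropyl in place of tert-butoxy on this carbonyl carbon shifts the read-out stays open.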